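The source may hold more compounds than are shown below. What is called first, only, known or untested is meant among the compounds shown, and "the series" means these compounds.

Compound 1 `Cc1nc(S(C)(=O)=O)ccc1Oc1ncnc(OC2CCN(C(=O)OC(C)F)CC2)c1F`: 65.5 nM
Compound 2 `Cc1nc(S(C)(=O)=O)ccc1Oc1ncnc(OC2CCN(C(=O)O[C@@H](C)CF)CC2)c1F`: 186 nM

Going by the values given here, in a functional assay on isolated protein for inhibition of Glucose-dependent insulinotropic receptor (Homo sapiens), read by HTRF and cAMP accumulation (on this read-out higher numbers stand for an effect only at larger amounts of compound and lower numbers for an effect already at smaller amounts), compound 2 gives 186 nM, the higher of the two numbers measured so far. Among the compounds with values here, compound 1 gives 65.5 nM, and the step of a 2.8-fold higher number from compound 1 to compound 2 (0.45 log units; beyond the scatter) is the only measured change available. Compound 3 `Cc1nc(S(C)(=O)=O)ccc1Oc1ncnc(OC2CCN(C(=O)C(C)(F)F)CC2)c1F` differs from compound 2 as follows: a group of 4 heavy atoms (2 carbon, 2 fluorine; no ring) in place of a group of 5 heavy atoms (3 carbon, 1 oxygen, 1 fluorine; no ring), on a carbonyl carbon. Within the data shown here, this is a change of a different kind from the one measured step: there the group on the oxygen was varied, here the oxygen itself leaves and a 1,1-difluoroethyl enters on the carbonyl carbon. The measured step of a 2.8-fold higher number from compound 1 to compound 2 (0.45 log units; beyond the scatter) was modest, and nothing measured speaks directly to removing the oxygen, so only a modest step in either direction, or none beyond the scatter, is expected. Compound 3 is expected to give about 150 nM, within a range from 45 nM to 500 nM. The expected step is a 1.2-fold lower number from compound 2 to compound 3 (0.09 log units; within the scatter).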

Compound 3, half-maximal effective concentration: 37 nM
The estimate for compound 3 lay 4.1-fold (0.61 log units) above the measured number, outside the stated range (below it).
By their numbers in this assay, from the lowest: compounds 3 and 1 (each within the scatter of the next); then compound 2.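

In this assay, the oxygen on the carbonyl carbon proves not to be needed at this position: a 1,1-difluoroethyl attached directly to that carbon gives a 5.0-fold lower number from compound 2 to compound 3 (0.70 log units; beyond the scatter) and so more than recovers what the earlier change of group on the oxygen had lost. Set against the 1-fluoroethyl on oxygen, the same kind of replacement gives a 1.8-fold lower number from compound 1 to compound 3 (0.25 log units; within the scatter) and therefore separates compound 1 and compound 3 by no more than the usual scatter, so the size of the gain depends on which oxygen-linked group is replaced. Nothing available explains why this replacement behaves as it does.

From the compounds shown here alone, what an ethyl without fluorine or a trifluoromethyl on the same carbonyl carbon would give remains open. Also open, going by these compounds, is whether an amine at that place, giving a urea, would match the 1,1-difluoroethyl.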